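The source may report more compounds than this note shows. Statements on the series, on what has been measured and on what is new or still open speak of the compounds shown alone.

Measured compounds:
- compound 1, `CCn1c(CNc2ccc(OC)cc2)nnc1SCC(=O)Nc1ccc(Cl)cc1`: 63500 nM
- compound 2, `Cc1ccc(SCC(=O)Nc2ccc3nc(NC(=O)c4ccc(C(F)(F)F)cc4)sc3c2)c(C)c1`: 1000 nM
- compound 3, `Nc1ccc(SCC(=O)Nc2ccc3nc(NC(=O)c4ccc(C(F)(F)F)cc4)sc3c2)cc1`: 1220 nM

In a functional assay on U2OS cells (Homo sapiens) for antiproliferative activity, read by MTT assay, with a stated time of 72 h (on this read-out higher numbers stand for weaker inhibition and lower numbers for stronger inhibition), compound 1 gives 63500 nM, while compound 2 gives 1000 nM and compound 3 gives 1220 nM. Compound 3 thus stands with compound 2, which shares its core, and far from compound 1, whose core is different and whose number is much higher. Going by the values given here, the one step among the measured compounds, a 1.2-fold higher number from compound 2 to compound 3 (0.09 log units; within the scatter), changed the group on the sulfur and left the number essentially where it was.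

Compound 4, `O=C(CSc1cccc(O)c1)Nc1ccc2nc(NC(=O)c3ccc(C(F)(F)F)cc3)sc2c1`, is the next step from compound 3. The change is 3-hydroxyphenyl in place of 4-aminophenyl on a sulfur. Among the compounds with values here, only the step from compound 2 to compound 3 bears on it, and that step was within the scatter, so a third group of the same size on the same sulfur is expected to give no step beyond the scatter in this assay, which the estimate a 1.1-fold higher number from compound 3 to compound 4 (0.03 log units; within the scatter) expresses. Compound 4 is therefore expected to give about 1300 nM, estimated to lie between 500 nM and 3500 nM.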

Compound 4, half-maximal inhibitory concentration: 630 nM
For compound 4 the middle estimate is 2.1-fold (0.31 log units) above the measured one; measured number inside the range.
By their numbers in this assay, from the lowest: compounds 4, 2 and 3 (each within the scatter of the next); then compound 1.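

With 3-hydroxyphenyl on the sulfur, the steps in this assay are a 1.9-fold lower number from compound 3 to compound 4 (0.29 log units; within the scatter) and a 1.6-fold lower number from compound 2 to compound 4 (0.20 log units; within the scatter) and neither leaves the scatter. The earlier compounds shown here showed this for a single exchange, whereas 2,4-dimethylphenyl, 4-aminophenyl and 3-hydroxyphenyl now all stand within the scatter of one another, so at this position the number holds even when the nitrogen of the group gives way to oxygen. Nothing in the available data explains why these groups give such similar numbers.

Going by these compounds, all three groups are phenyl rings, so it stays open whether a plain ethyl chain, a cyclohexyl ring or a phenyl ring carrying a carboxylic acid on this sulfur would keep the number in the same range. The much higher number of compound 1 also stays unassigned, as it differs from the others in more than one place.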